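Working notes: step from compound 3 to compound 4

The source may hold more compounds than are shown below. What is called first, only, known or untested is meant among the compounds shown, and "the series" means these compounds.

compound 1 `C[C@@]1(c2cc(NC(=O)c3cnc(OCF)cn3)ccc2F)C=C(CF)OC(N)=N1`: 52%
compound 2 `C[C@@]1(c2cc(NC(=O)c3cnc(C(F)F)cn3)ccc2F)C=C(CF)OC(N)=N1`: 44%
compound 3 `C[C@@]1(c2cc(NC(=O)c3ncc(OCF)nc3N)ccc2F)C=C(CF)OC(N)=N1`: 35%

In an ADME assay on microsomes from liver (Rattus norvegicus, strain Crj;CD(SD)) for metabolic stability, read by LC-MS, using NADPH, with a stated time of 30 min, tested at 0.1 uM (a lower number here means that less of the compound is left, a higher number that more of the compound is left), compound 3 gives 35%. The comparison with the first compound shows a number 17 percentage points lower from compound 1 to compound 3 (beyond the scatter), and the comparison with the second shows a number 9 percentage points lower from compound 2 to compound 3 (within the scatter). Compound 3 therefore stands clearly apart only from compound 1.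

The next structure is compound 4 `C[C@@]1(c2cc(NC(=O)c3coc(CF)n3)ccc2F)C=C(CF)OC(N)=N1`, with the change 2-(fluoromethyl)-1,3-oxazol-4-yl in place of 3-amino-5-(fluoromethoxy)pyrazin-2-yl on a carbonyl carbon. Within the data shown here, no measured step covers this five-membered aromatic ring, so the evidence is indirect. The closest guide is the amino step, a number 17 percentage points lower from compound 1 to compound 3 (beyond the scatter), since the entering group has no amino substituent. The exchange of the fluorinated group, a number 8 percentage points lower from compound 1 to compound 2 (within the scatter), stayed small. Together these suggest a modest move upward, with wide uncertainty over the untested ring. The expected step is a number 11 percentage points higher from compound 3 to compound 4 (beyond the scatter). For compound 4 the estimated value is 46%, with an expected range of 28% to 64%.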

Compound 4, percent of the compound remaining: 39%
Compound 4: the middle estimate sits 7 percentage points above what was measured; measured number inside the range.
By their numbers in this assay, from the lowest: compounds 3, 4, 2 and 1 (each within the scatter of the next, the first and the last beyond it).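

In this assay, 2-(fluoromethyl)-1,3-oxazol-4-yl on the carbonyl carbon gives a number 4 percentage points higher from compound 3 to compound 4 (within the scatter) against 3-amino-5-(fluoromethoxy)pyrazin-2-yl and a number 5 percentage points lower from compound 2 to compound 4 (within the scatter) against 5-(difluoromethyl)pyrazin-2-yl, so a five-membered aromatic ring is tolerated here without a step beyond the scatter from either of these groups. Among these compounds, the only step that clears the scatter is against 5-(fluoromethoxy)pyrazin-2-yl, with a number 13 percentage points lower from compound 1 to compound 4 (beyond the scatter), so the smaller ring does not match that group in this read-out. No measurement available here accounts for these steps.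

The compounds shown do not separate the contribution of the oxazole ring from that of its fluoromethyl group. An oxazole carrying methyl, difluoromethyl or an amine in place of fluoromethyl would make that comparison readable.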